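From carbamoyl to methoxycarbonyl: what compound 4 may tolerate

A few compounds are considered here, and "the series" means these few. Any claim that something is new, unique, unknown or untested is made for them only; others in the source may bear on it.

Of the compounds shown here, three sharing one core have been measured in a functional assay on HEL cells (Homo sapiens); a higher number here means that more compound is tolerated, a lower number that less compound is tolerated. Compound 1 `Cc1cn([C@@H]2O[C@H](CO[Si](C)(C)C(C)(C)C)[C@@]3(OS(=O)(=O)C=C3NCC(=O)C(=O)N3CCC3)[C@H]2O[Si](C)(C)C(C)(C)C)c(=O)n(C)c1=O` gives 84400 nM. Compound 2 `Cc1cn([C@@H]2O[C@H](CO[Si](C)(C)C(C)(C)C)[C@@]3(OS(=O)(=O)C=C3NCC(=O)OCc3ccccc3)[C@H]2O[Si](C)(C)C(C)(C)C)c(=O)n(C)c1=O` gives > 200000 nM, which is a limit of the assay and not a number. Among the measured compounds shown here, compound 3 `Cc1cn([C@@H]2O[C@H](CO[Si](C)(C)C(C)(C)C)[C@@]3(OS(=O)(=O)C=C3NCCC(N)=O)[C@H]2O[Si](C)(C)C(C)(C)C)c(=O)n(C)c1=O` gives 14800 nM, the lowest number so far, with compound 1 its nearest neighbour.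

Compound 4 `COC(=O)CCNC1=CS(=O)(=O)O[C@@]12[C@@H](CO[Si](C)(C)C(C)(C)C)O[C@@H](n1cc(C)c(=O)n(C)c1=O)[C@@H]2O[Si](C)(C)C(C)(C)C` differs from compound 3 in one place, with methoxy in place of amino on a carbonyl carbon, so that 2-carbamoylethyl becomes 2-(methoxycarbonyl)ethyl (methoxy in place of amino on a carbonyl carbon). For the measured compounds named here, no measured step makes exactly this change. The closest is the large one, an at least 13-fold lower number from compound 2 to compound 3 (1.13 log units; beyond the scatter), where carbamoylmethyl replaces benzyloxycarbonyl. Read backwards, it suggests that a group of this kind could raise the number in this assay. The modest step of a 5.7-fold lower number from compound 1 to compound 3 (0.76 log units; beyond the scatter) also leaves compound 3 lower. However, methoxy is not benzyloxy and the chains differ, so only part of the larger step is expected to carry over.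

The expected change is a 3.0-fold higher number from compound 3 to compound 4 (0.48 log units; beyond the scatter), a modest rise. Compound 4 is expected at about 45000 nM, with an estimated range from 14000 nM to 160000 nM.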

Compound 4, half-maximal cytotoxic concentration: 94000 nM
Estimate against measurement, compound 4: 2.1-fold (0.32 log units) below; the range from low to high includes it.
By their numbers in this assay, from the lowest: compound 3; then compounds 1 and 4 (each within the scatter of the next). At a limit, above all of these: compound 2.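

In this assay, among the compounds shown here, putting methoxy in place of amino on a carbonyl carbon, with the chain otherwise unchanged, gives a 6.4-fold higher number from compound 3 to compound 4 (0.80 log units; beyond the scatter), so this one change alone is enough to move the number beyond the scatter, whereas the earlier steps each replaced a larger part of the side chain. The same compound 4 also shows a 1.1-fold higher number from compound 1 to compound 4 (0.05 log units; within the scatter), which means that two quite different side chains, 2-(methoxycarbonyl)ethyl and the one carrying the azetidine amide, cannot be told apart in this assay. Compound 2 stands at a limit of the assay and not at a number, so an at least 2.1-fold lower number from compound 2 to compound 4 (0.32 log units; beyond the scatter) fixes only one side of that gap: the limit of > 200000 nM in this assay, at which 1 of the 4 values shown sits.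

The compounds shown do not separate the loss of the amino, with its hydrogen-bond donor, from the arrival of the methoxy, so it stays unclear which of the two goes with the rise. Methylamino or hydroxy on the same carbonyl carbon, the latter giving a carboxylic acid, would help to separate them, and ethoxy or a longer chain would show how far the rise extends.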